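This account rests on a few compounds, and the source may have more. Where it says the series, first, only, none or still open, it means among the compounds named here.

Compound 1 `C[C@]1(CN2CCc3nc(-c4ccc(OC(F)(F)F)cc4)ccc3C2)Cn2cc([N+](=O)[O-])nc2O1` is the starting point of this comparison. Among the measured compounds shown here, in an ADME assay on Vero cells (Chlorocebus sabaeus) for cytotoxicity, read by MTT assay, with a stated time of 72 h (a lower number here means that less compound is tolerated, a higher number that more compound is tolerated), compound 1 gives "not determined" (no result reported), so no number of its own places it on the scale, and the only measured value shown comes from a related compound. Compound 2 `C[C@]1(CN2CCc3nc(-c4ccc(F)cc4)oc3C2)Cn2cc([N+](=O)[O-])nc2O1` shares much of its core with compound 1 but differs elsewhere in the molecule. In this assay compound 2 reaches > 32 ug/mL, which is a limit of the assay rather than a number. For the measured compounds named here, the single measured value therefore sits at the limit of > 32 ug/mL in this assay, at which 1 of the 2 values shown sits, and no step between two measured compounds is available to show how a change at the outer ring moves the read-out.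

Compound 3 `C[C@]1(CN2CCc3nc(-c4cc(F)ccc4Cl)ccc3C2)Cn2cc([N+](=O)[O-])nc2O1` has not yet been measured. It differs from compound 1 in one place: 2-chloro-5-fluorophenyl in place of 4-(trifluoromethoxy)phenyl on an aromatic carbon. Going by the values given here, with no measured step to lean on, the expected change in this assay is none beyond the usual scatter, in either direction. For compound 3 the half-maximal cytotoxic concentration in this assay is estimated at 32 ug/mL, within a range from 16 ug/mL to 64 ug/mL.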

Compound 3, half-maximal cytotoxic concentration: > 32 ug/mL
Compound 3: only a limit was reported (the forecaster's own chance of this, stated with the estimate: 70%); the middle value sits exactly at the limit.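

In this assay compound 3 gives > 32 ug/mL as a limit of the assay, not a number. Among the compounds shown here, compound 1 has no reported result, so no step from compound 1 to compound 3 can be read. The compounds shown leave open where compound 3 truly stands and whether replacing 4-(trifluoromethoxy)phenyl with 2-chloro-5-fluorophenyl changes this read-out.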